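Hydroxy in place of sulfanyl on a weakly inhibiting core

The source may report more compounds than this note shows. Statements on the series, on what has been measured and on what is new or still open speak of the compounds shown alone.

Compound 1 is `CCCc1nc(C)c2c(C)nnc(SC)n12`; in a functional assay for inhibition, with Homo sapiens as the target (on this read-out higher numbers stand for weaker inhibition and lower numbers for stronger inhibition), compound 1 reaches only a limit of the assay, > 48000 nM.
Compound 2 is `CCCc1nc(C)c2c(C3CC3)nnc(O)n12`; in this assay compound 2 likewise gives only a limit, > 48000 nM.
Compound 3 is `CCCc1nc(C)c2c(C)nnc(S)n12`; in this assay compound 3 gives 45000 nM.

Within the data shown here, compound 3 thus holds the only number in the set; the other two values are limits, as the limit of > 48000 nM in this assay, at which 2 of the 3 values shown sit, shows. Among the measured compounds shown here, the one measured step, an at least 1.0-fold lower number from compound 1 to compound 3 (0.02 log units; that floor lies within the scatter), is a change on the sulfur side of the core and lies within the scatter, so it offers no foothold for a shift in either direction.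

Compound 4 is `CCCc1nc(C)c2c(C)nnc(O)n12`. The change from compound 3 is hydroxy in place of sulfanyl on an aromatic carbon. For the measured compounds named here, no measured step covers this exchange. Compound 2, which also bears a hydroxy at that place, reached only a limit, so nothing argues for stronger inhibition. The step of a 1.3-fold higher number from compound 3 to compound 4 (0.12 log units; within the scatter) is therefore expected to lie within the scatter or toward a weaker number, quite possibly ending at the limit again. Compound 4 is estimated at 60000 nM, with a range from 30000 nM to 150000 nM.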

Compound 4, half-maximal inhibitory concentration: 14000 nM
Compound 4: the middle estimate sits 4.3-fold (0.63 log units) above what was measured; measured number below the stated range.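

The exchange of sulfanyl for hydroxy at this place, between two ring nitrogen atoms, moves the result in this assay beyond the scatter, with a 3.2-fold lower number from compound 3 to compound 4 (0.51 log units; beyond the scatter), and replacing methylsulfanyl with hydroxy does the same, with an at least 3.4-fold lower number from compound 1 to compound 4 (0.53 log units; beyond the scatter). Hydroxy alone does not set the level, since methyl in place of cyclopropyl with the hydroxy kept gives an at least 3.4-fold lower number from compound 2 to compound 4 (0.53 log units; beyond the scatter). The steps from compound 1 and from compound 2 are floors only, because each of these compounds stops at a limit: the limit of > 48000 nM in this assay, at which 2 of the 4 values shown sit.

From the compounds shown here alone, whether an amine or a methoxy group at the hydroxy position would carry the gain further remains open. Also open, going by these compounds, is whether ethyl in place of the methyl that replaced cyclopropyl, or a longer chain in place of propyl, would change the number.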